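A few compounds are considered here, and "the series" means these few. Any claim that something is new, unique, unknown or untested is made for them only; others in the source may bear on it.

Compound 1 `Cc1cn([C@@H]2O[C@H](CO[Si](C)(C)C(C)(C)C)[C@@]3(OS(=O)(=O)C=C3NCC(=O)C(=O)N3CCC3)[C@H]2O[Si](C)(C)C(C)(C)C)c(=O)n(C)c1=O` carries, on an amine nitrogen of the shared core, a (((azetidin-1-yl)carbonyl)carbonyl)methyl chain. In a functional assay on HEL cells (Homo sapiens) for cytotoxicity, read by microscopy (on this read-out lower numbers stand for higher toxicity in this test and higher numbers for lower toxicity in this test), compound 1 gives 65000 nM, the lowest of the two plain numbers on hand. Compound 2 `CC(=O)NC1=CS(=O)(=O)O[C@@]12[C@@H](CO[Si](C)(C)C(C)(C)C)O[C@@H](n1cc(C)c(=O)n(C)c1=O)[C@@H]2O[Si](C)(C)C(C)(C)C` has an acetyl in place of that chain; for compound 2 this assay returns only a limit, >= 80000 nM. Compound 3 `COC(=O)CC(=O)NC1=CS(=O)(=O)O[C@@]12[C@@H](CO[Si](C)(C)C(C)(C)C)O[C@@H](n1cc(C)c(=O)n(C)c1=O)[C@@H]2O[Si](C)(C)C(C)(C)C` carries a ((methoxycarbonyl)methyl)carbonyl group instead, and in this assay compound 3 gives 400000 nM. Both measured steps away from compound 1 replace the azetidine-bearing chain and move the number upward, toward lower toxicity: an at least 1.2-fold higher number from compound 1 to compound 2 (0.09 log units; that floor lies within the scatter), and a 6.2-fold higher number from compound 1 to compound 3 (0.79 log units; beyond the scatter). Compound 4 `Cc1cn([C@@H]2O[C@H](CO[Si](C)(C)C(C)(C)C)[C@@]3(OS(=O)(=O)C=C3NCC(=O)C(=O)O)[C@H]2O[Si](C)(C)C(C)(C)C)c(=O)n(C)c1=O` keeps the chain of compound 1 but opens its end: hydroxy in place of azetidin-1-yl on a carbonyl carbon. For the measured compounds named here, no measured step makes exactly this change, so the expectation rests on the two steps from compound 1, which point the same way, one of them only as a floor set by the limit of >= 80000 nM in this assay, at which 1 of the 3 values shown sits. The step to compound 4 is therefore expected to be a 2.3-fold higher number from compound 1 to compound 4 (0.36 log units; beyond the scatter). Compound 4 is expected to give 150000 nM in this assay, with a range from 60000 nM to 400000 nM, and with a real chance that only a limit is returned.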

Compound 4, minimum cytotoxic concentration: 400000 nM
Compound 4: the middle estimate sits 2.7-fold (0.43 log units) below what was measured; measured number inside the range.
By their numbers in this assay, from the lowest: compound 1; then compounds 3 and 4 (each within the scatter of the next).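

The azetidin-1-yl group alone accounts for a sizeable shift: with the rest of the chain kept and hydroxy in place of azetidin-1-yl on the carbonyl carbon, this assay shows a 6.2-fold higher number from compound 1 to compound 4 (0.79 log units; beyond the scatter). The earlier steps shown here replaced the whole chain, so they could not show that a change confined to its end reaches the same level as a different chain altogether, and the comparison of the two chains gives no change at the digits printed from compound 3 to compound 4 (within the scatter). Compound 2 has only a limit, so its steps to compound 3 and compound 4 cannot be read: the limit of >= 80000 nM in this assay, at which 1 of the 4 values shown sits.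

This single swap removes a ring and brings in a hydroxy group together, so the compounds shown do not separate the loss of azetidin-1-yl from the arrival of hydroxy. Going by these compounds, a methyl ester at this carbonyl carbon, or an amide of another amine such as pyrrolidin-1-yl or dimethylamino, could help tell these apart, and whether such compounds would fall with compound 1 or with compound 4 remains open.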